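Moving the chlorine: from compound 2 to compound 3

The compounds below may be only part of what the source reports. "The series", "measured", "known", "first", "only" and "open" are said of these compounds alone.

Measured so far in a functional assay on A-375 cells (Homo sapiens) for antiproliferative activity, read by MTT assay, with a stated time of 24 h; a higher number here means a weaker inhibitor, a lower number a stronger inhibitor:
Compound 1 `COc1cc(OC)c(-c2coc3cc(OCc4ccccc4C(F)(F)F)ccc3c2=O)cc1OC`: > 10000 nM, a limit and not a number
Compound 2 `COc1cc(OC)c(-c2coc3cc(OCc4cccc(Cl)c4)ccc3c2=O)cc1OC`: 980 nM

Among the measured compounds shown here, compound 2 holds the only actual number so far, 980 nM. The other result is a limit. Compound 3 `COc1cc(OC)c(-c2coc3cc(OCc4ccccc4Cl)ccc3c2=O)cc1OC` keeps the shared core and has 2-chlorophenyl in place of 3-chlorophenyl on a saturated chain carbon bound to an oxygen on an aromatic ring. For the measured compounds named here, only one measured step bears on this: an at least 10-fold lower number from compound 1 to compound 2 (1.00 log units; beyond the scatter). That step replaced 2-(trifluoromethyl)phenyl, so it changed more than the change here does, and it is a single pair. Going by an at least 10-fold lower number from compound 1 to compound 2 (1.00 log units; beyond the scatter), a loss of activity is expected, though a milder one, with the chlorine kept. The expected change is a 2.6-fold higher number from compound 2 to compound 3 (0.41 log units; beyond the scatter). Compound 3 is estimated at 2500 nM, with an expected range of 600 nM to 9000 nM.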

Compound 3, half-maximal inhibitory concentration: 2020 nM
Compound 3: the middle estimate sits 1.2-fold (0.09 log units) above what was measured, within the range that was stated.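

Moving the chlorine, with the atoms of the group unchanged, is enough to shift the result in this assay: a 2.1-fold higher number from compound 2 to compound 3 (0.31 log units; beyond the scatter). Compound 2 and compound 3 thus show that at this place, the position of the chlorine on the phenyl group matters, which the earlier step could not show because it changed both the substituent and its position. Exchanging the substituent while keeping the 2-substituted pattern also shifts the result, an at least 4.9-fold lower number from compound 1 to compound 3 (0.69 log units; beyond the scatter), but compound 1 gives only a limit and not a number, so the full size of this step stays unknown: the limit of > 10000 nM in this assay, at which 1 of the 3 values shown sits.

Going by these compounds, whether the chlorine itself is needed remains open, and a plain phenyl, or a nitrile or an amine in place of the chlorine, would address that. A longer chain in place of the saturated chain carbon would show whether the length of this link matters.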